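Amiloride-type series: ring closure at the amino substituent

The compounds below may be only part of what the source reports. "The series", "measured", "known", "first", "only" and "open" are said of these compounds alone.

Measured so far:
Compound 1, `NC(N)=NC(=O)c1nc(Cl)c(NCc2ccc(Cl)cc2)nc1N`: 46%
Compound 2, `CCCNc1nc(N)c(C(=O)N=C(N)N)nc1Cl`: 24%
Compound 3, `NC(N)=NC(=O)c1nc(Cl)c(NCc2cccc(F)c2)nc1N`: 29%

All three share one core and differ only in the group on the nitrogen bound to the aromatic ring, read in an assay for inhibition of acid-sensing ion channel 3 (Homo sapiens), read by patch clamp, tested at 1 uM; on this read-out lower numbers stand for less inhibition and higher numbers for more inhibition at the one concentration tested (going by the name of the read-out). Compound 2 sits at the low end of the three numbers: the step of a number 5 percentage points higher from compound 2 to compound 3 (within the scatter) is within the scatter, while the step of a number 22 percentage points lower from compound 1 to compound 2 (beyond the scatter) and the step of a number 17 percentage points lower from compound 1 to compound 3 (beyond the scatter) are beyond it, so only compound 1 stands apart.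

Compound 4, `NC(N)=NC(=O)c1nc(Cl)c(N2CCCC2)nc1N`, is not yet measured. Its change from compound 2 is pyrrolidin-1-yl in place of propylamino on an aromatic carbon. Within the data shown here, no measured step covers this kind of change; the steps that touch the same site, a number 22 percentage points lower from compound 1 to compound 2 (beyond the scatter) and a number 5 percentage points higher from compound 2 to compound 3 (within the scatter), show that exchanging one small group for another at this nitrogen moves this assay modestly or not at all. A step of a number 1 percentage points higher from compound 2 to compound 4 (within the scatter) of no size beyond the scatter is therefore expected. Compound 4 is expected to give 25%, with a range from 10% to 42%.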

Compound 4, a percentage reported as inhibition, at one concentration (the size of the read-out at that concentration, not a potency): 12%
For compound 4 the middle estimate is 13 percentage points above the measured one; low and high end bracket the measured number.
By their numbers in this assay, from the lowest: compound 4; then compounds 2 and 3 (each within the scatter of the next); then compound 1.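

In this assay, among these compounds, the earlier compounds varied only open-chain and benzyl-type groups on this nitrogen, whereas tying the substituent into a ring gives a number 12 percentage points lower from compound 2 to compound 4 (beyond the scatter). The change is not a single one: the entering pyrrolidin-1-yl brings a five-membered non-aromatic ring and has 0 hydrogen-bond donors where propylamino has 1, and this one step cannot separate the two. Nothing available explains the lower number.

Still open, going by these compounds, is whether diethylamino, which has no ring and no hydrogen on this nitrogen, would read closer to compound 4 or to compound 2. Also open, on these data alone, is whether a piperidin-1-yl or morpholin-4-yl group would read like pyrrolidin-1-yl at this position.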